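The source may hold more compounds than are shown below. What is called first, only, known or untested is meant among the compounds shown, and "the series" means these compounds.

Three sulfonamides built on one shared core have been read in a functional assay on cells (leukaemia cell line, Homo sapiens) for inhibition, read by sulforhodamine B assay, with a stated time of 48 h; a lower number here means a stronger inhibitor of growth, a higher number a weaker inhibitor of growth. Compound 1 `O=S(=O)(Nc1cc(Cl)ccc1Cl)c1ccc(-c2cnc(C3CC3)o2)cc1` gives only a limit, > 100000 nM. Compound 2 `O=S(=O)(Nc1cc(F)cc(Cl)c1)c1ccc(-c2cnc(C3CC3)o2)cc1` gives 77500 nM, and compound 3 `Cc1cc(Cl)cc(NS(=O)(=O)c2ccc(-c3cnc(C4CC4)o3)cc2)c1` gives 7040 nM, the lowest number of the set. Compound 4 `Cc1cc(F)cc(NS(=O)(=O)c2ccc(-c3cnc(C4CC4)o3)cc2)c1` is unmeasured and differs from compound 3 by one change: fluoro in place of chloro on an aromatic carbon, meta to a methyl group.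

Within the data shown here, no measured step makes this exact swap. The nearest is an 11-fold lower number from compound 2 to compound 3 (1.04 log units; beyond the scatter), where methyl takes the place of fluoro while chloro stays. The steps of an at least 14-fold lower number from compound 1 to compound 3 (1.15 log units; beyond the scatter) and an at least 1.2-fold lower number from compound 1 to compound 2 (0.11 log units; that floor lies within the scatter) alter the ring pattern more broadly and bear on it less directly. Among the measured compounds shown here, since compound 2, the only measured fluoro compound, reads 77500 nM, fluoro entering is expected to raise the number, though probably less sharply, as compound 4 keeps the methyl. The expected change is a 3.6-fold higher number from compound 3 to compound 4 (0.55 log units; beyond the scatter), a rise in the number. For compound 4 the estimated value in this assay is 25000 nM, with an expected range from 8000 nM to 80000 nM.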

Compound 4, concentration for total growth inhibition: 7250 nM
Compound 4: middle estimate off by 3.4-fold (0.54 log units), on the high side; measured number outside the range, below it.
By their numbers in this assay, from the lowest: compounds 3 and 4 (each within the scatter of the next); then compound 2. At a limit, above all of these: compound 1.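

In this assay, fluoro and chloro, meta to a methyl group, read level with each other: a 1.0-fold higher number from compound 3 to compound 4 (0.01 log units; within the scatter). The large gain that came with methyl while chloro stayed also appears while fluoro stays, so it does not hang on which of these two halogens is kept: an 11-fold lower number from compound 2 to compound 3 (1.04 log units; beyond the scatter), and likewise an 11-fold lower number from compound 2 to compound 4 (1.03 log units; beyond the scatter). Compound 1 gives only a limit, so an at least 13-fold lower number from compound 1 to compound 4 (1.13 log units; beyond the scatter) is a floor and not a measured size: the limit of > 100000 nM in this assay, at which 1 of the 4 values shown sits.

On these data alone, whether an amine or a methoxy group in this place would read level with fluoro and chloro stays open. So does whether the two halogens would still match with an ethyl group or a longer chain in place of the methyl.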